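From 4-chlorophenyl to 2,3-dichlorophenyl

A few compounds are considered here, and "the series" means these few. Any claim that something is new, unique, unknown or untested is made for them only; others in the source may bear on it.

In a functional assay on B16-F10 cells (Mus musculus) for cytotoxicity (a lower number here means a stronger inhibitor, a higher number a weaker inhibitor), compound 1 `O=c1oc2ccccc2c2nc3c(ccc4cc[nH]c43)c(-c3ccc(C(F)(F)F)cc3)c12` gives 70700 nM, and compound 2 `O=c1oc2ccccc2c2nc3c(ccc4cc[nH]c43)c(-c3ccc(Cl)cc3)c12` stands level with it at 70700 nM. Compound 3 `O=c1oc2ccccc2c2nc3c(ccc4cc[nH]c43)c(-c3cccc(Cl)c3Cl)c12` carries 2,3-dichlorophenyl in place of 4-chlorophenyl on an aromatic carbon. Going by the values given here, only one measured step bears on this change: no change at the digits printed from compound 1 to compound 2 (within the scatter). That step is a different substitution and offers a single precedent, so no shift beyond the scatter is expected in this assay. The expected step is a 1.1-fold lower number from compound 2 to compound 3 (0.04 log units; within the scatter). Compound 3 is estimated at 65000 nM, with an expected range of 25000 nM to 150000 nM.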

Compound 3, half-maximal inhibitory concentration: 70700 nM
The estimate for compound 3 lay 1.1-fold (0.04 log units) below the measured number; the measured number falls inside the stated range.
By their numbers in this assay, from the lowest: compounds 1, 2 and 3 (each within the scatter of the next).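

In this assay the change to 2,3-dichlorophenyl gives no change at the digits printed from compound 2 to compound 3 (within the scatter) and the change from 4-(trifluoromethyl)phenyl gives no change at the digits printed from compound 1 to compound 3 (within the scatter) on the same aromatic carbon. So a second chlorine and a different placement of chlorine on this phenyl ring, and not only the exchange of one single group for another, leave the number where it stood. No measurement at hand explains this flat reading. The compounds shown leave open whether a phenyl ring carrying an amine or a carboxylic acid, or a longer alkyl chain in its place, would move the number at all.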